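The compounds below may be only part of what the source reports. "The series", "measured", "known", "first", "only" and "open" are said of these compounds alone.

In a physicochemical assay for solubility, in phosphate buffer, measured as thermodynamic solubility, at pH 7.4 (on this read-out lower numbers stand for lower solubility and higher numbers for higher solubility), compound 1 `CS(=O)(=O)NC(=O)CCc1cn(-c2ccccc2)nc1-c1ccc(Cl)cc1` gives 200000 nM. Compound 2 `C[S+]([O-])c1ccc(-n2cc(CCC(=O)NS(C)(=O)=O)c(-c3ccc(Cl)cc3)n2)cc1` gives 200000 nM, and compound 3 `CS(=O)(=O)NC(=O)CCc1cn(-c2ccc(Br)cc2)nc1-c1cccnc1` gives 200000 nM, so compound 3 stands level with the other two on these numbers. Compound 4 `CS(=O)(=O)NC(=O)CCc1cn(-c2ccc(Br)cc2)nc1-c1ccc(N)cc1` has not yet been measured. It differs from compound 3 in one place: 4-aminophenyl in place of pyridin-3-yl on an aromatic carbon. Among the measured compounds shown here, the exchange is 4-aminophenyl in place of pyridin-3-yl on an aromatic carbon, and no measured step covers it directly. For the measured compounds named here, the only measured step between compounds that differ in one place is no change at the digits printed from compound 1 to compound 2 (within the scatter), which stays within the scatter although a hydrogen atom on an aromatic carbon gives way to a larger group. That step concerns another part of the structure, so it is only a loose guide. With it and the value of compound 3 at 200000 nM as the basis, no change beyond the scatter is expected, in either direction. The estimated step is no change at the digits printed from compound 3 to compound 4 (within the scatter). In this assay, the estimate for compound 4 is 200000 nM, with an expected range of 80000 nM to 300000 nM.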

Compound 4, solubility: 160000 nM
Estimate against measurement, compound 4: 1.3-fold (0.10 log units) above, within the range that was stated.
By their numbers in this assay, from the lowest: compounds 4, 1, 2 and 3 (each within the scatter of the next).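

In this assay, among the compounds shown here, the first one-place exchange at this position, on the aromatic carbon that carries the pyridin-3-yl group in compound 3, gives a 1.3-fold lower number from compound 3 to compound 4 (0.10 log units; within the scatter). For the compounds shown here, the only earlier step, no change at the digits printed from compound 1 to compound 2 (within the scatter), concerned another part of the structure, so this position can now be said to take either 4-aminophenyl or pyridin-3-yl, with the 4-bromophenyl group held in place, without the read-out leaving the scatter. Nothing measured here offers an explanation for this result.

Going by these compounds, whether a carboxylic acid or a longer chain on this same ring carbon would read the same remains open, since only these two groups are compared here. On these data alone, all four compounds carry the 2-((methylsulfonyl)carbamoyl)ethyl group, so the effect of an amine or a carboxylic acid in its place also remains open.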